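A few compounds are considered here, and "the series" means these few. Any claim that something is new, unique, unknown or untested is made for them only; others in the source may bear on it.

Compound 1 `CC/C=C\C[C@H]1C(=O)C=C[C@H]1CC(=O)OCc1ccccc1` is the reference point of this short series. In a functional assay on RAW264.7 cells (Mus musculus) for inhibition, read by ELISA, with a stated time of 24 h (on this read-out higher numbers stand for an effect only at larger amounts of compound and lower numbers for an effect already at smaller amounts), compound 1 gives 20000 nM, the lowest of the three numbers recorded. Within the data shown here, compound 3 `CC/C=C\C[C@H]1C(=O)C=C[C@H]1CC(=O)OCCOCCOCCOC` gives 35000 nM in this assay, a value that lies within the scatter of compound 1, while compound 2 `CC/C=C\C[C@H]1C(=O)C=C[C@H]1CC(=O)OCCOCCOCCO` gives 42000 nM, the only number separated from compound 1 by more than the scatter. Among the measured compounds shown here, the one measured step that bears on the change at hand is a 2.1-fold higher number from compound 1 to compound 2 (0.32 log units; beyond the scatter), a modest shift; the further step a 1.2-fold lower number from compound 2 to compound 3 (0.08 log units; within the scatter) alters nothing beyond the scatter. Compound 4 `CC/C=C\C[C@H]1C(=O)C=C[C@H]1CC(=O)OC(C)CC` differs from compound 1 by sec-butyl in place of benzyl on an oxygen next to a carbonyl group. For the measured compounds named here, since the only precedent for replacing the benzyl group is the modest rise seen in a 2.1-fold higher number from compound 1 to compound 2 (0.32 log units; beyond the scatter), a small rise in number, or none beyond the scatter, is expected for compound 4, which is to say a 1.3-fold higher number from compound 1 to compound 4 (0.10 log units; within the scatter). Compound 4 is therefore estimated at 25000 nM in this assay, within an expected range from 12000 nM to 55000 nM.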

Compound 4, half-maximal effective concentration: 22000 nM
Estimate against measurement, compound 4: 1.1-fold (0.06 log units) above; the range from low to high includes it.
By their numbers in this assay, from the lowest: compounds 1, 4, 3 and 2 (each within the scatter of the next, the first and the last beyond it).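

Replacing benzyl with sec-butyl on an oxygen next to a carbonyl group gives a 1.1-fold higher number from compound 1 to compound 4 (0.04 log units; within the scatter) in this assay and so leaves the number where it was. The earlier step at this place had brought in a chain with further oxygens, whereas this one shows that a branched group of carbon only, with no ring and fewer heavy atoms, can stand here without a shift beyond the scatter. The six-membered aromatic ring of benzyl is thus not needed to hold the number at this level, and no measurement is available to explain this result.

From the compounds shown here alone, it remains open how an amine, a carboxylic acid or a longer chain would read at this place. The compounds shown also do not reveal whether any group here can bring the number clearly below that of compound 1.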